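Propargyl ether to free hydroxyl on a benzimidazole-side chain

The source may hold more compounds than are shown below. What is called first, only, known or untested is meant among the compounds shown, and "the series" means these compounds.

Compound 1 `C#CCOCCn1c(N2CCN(C)CC2)nc2ccccc21`: in a functional assay on ileum for inhibition of histamine H1 receptor (Cavia porcellus) (on this read-out lower numbers stand for stronger inhibition and higher numbers for weaker inhibition), compound 1 gives 12 nM.
Compound 2 `CCOCCn1c(N2CCN(c3ccccc3)CC2)nc2ccccc21`: in this assay compound 2 gives > 10000 nM, a limit of the assay.

Within the data shown here, of the two compounds measured, compound 1 is the only one that returns a number in this assay; the other result sits at the limit of > 10000 nM in this assay, at which 1 of the 2 values shown sits. Among the measured compounds shown here, no pair of measured compounds differs in a single place, so no measured step is available, and the two values are simply what they are: a number for compound 1 and a limit for compound 2.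

The unmeasured compound 3 `CN1CCN(c2nc3ccccc3n2CCO)CC1` is reached from compound 1 by a single change, (hydrogen in place of propargyl on an oxygen on a saturated carbon). Without a measured step of this kind to lean on, the size and direction of the effect in this assay are uncertain; a moderate loss of inhibition, somewhat beyond the scatter, seems the most likely outcome, though a result within the scatter of compound 1 cannot be ruled out. Compound 3 is therefore expected to give about 40 nM in this assay, within a range of 8 nM to 300 nM. This estimate means a step from compound 1 to compound 3 of a 3.3-fold higher number from compound 1 to compound 3 (0.52 log units; beyond the scatter), expected rather than known.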

Compound 3, half-maximal inhibitory concentration: 410 nM
For compound 3 the middle estimate is 10-fold (1.01 log units) below the measured one; the measured number lies above the stated range.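

Among these compounds, the first single-place step shows that the group on this oxygen matters in this assay: putting hydrogen in place of propargyl gives a 34-fold higher number from compound 1 to compound 3 (1.53 log units; beyond the scatter). The change from 2-(propargyloxy)ethyl to 2-hydroxyethyl weakens inhibition without taking it out of the measurable range, as compound 3 still returns a number rather than a limit. None of the results shown identifies what lies behind this loss.

On these data alone, whether the loss is specific to propargyl remains open, as does the outcome with a methyl ether on this oxygen, or with an amine or a carboxylic acid in place of the hydroxyl. Compound 2, an ethyl ether whose > 10000 nM is a limit of the assay, differs from compound 1 in more than one place and so cannot answer these questions.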